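Hydantoin benzylidene series: ester to amide on the aryl ring

The source may hold more compounds than are shown below. What is called first, only, known or untested is meant among the compounds shown, and "the series" means these compounds.

Measured compounds:
compound 1, `O=C1N/C(=C\c2ccc(Br)cc2)C(=O)N1c1ccc(Cl)cc1`, 46600 nM in a functional assay on NCI-H292 cells (Homo sapiens) for antiproliferative activity; a higher number here means a weaker inhibitor, a lower number a stronger inhibitor
compound 2, `CCOC(=O)c1ccc(N2C(=O)N/C(=C\c3ccc(O)cc3)C2=O)cc1`, > 200000 nM in this assay
compound 3, `O=C(Nc1ccc(Cl)cc1)c1cccc(N2C(=O)N/C(=C\c3ccc(O)cc3)C2=O)c1`, 125000 nM in this assay

For compound 2 the result in this assay is only a limit, > 200000 nM, and not a number. Compound 2 therefore stands at the limit of > 200000 nM in this assay, at which 1 of the 3 values shown sits, the weak end of what this series has shown so far; compound 1 with 46600 nM and compound 3 with 125000 nM both give numbers.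

The step to be followed is from compound 2 to compound 4, `O=C(c1ccc(N2C(=O)N/C(=C\c3ccc(O)cc3)C2=O)cc1)N1CCCC1`. The difference, (pyrrolidin-1-yl in place of ethoxy on a carbonyl carbon), in words: pyrrolidin-1-yl in place of ethoxy on a carbonyl carbon. Among the measured compounds shown here, no measured pair carries this same change, so there is no step to lean on. Compound 3 shows that a carboxamide on the aryl ring is compatible with a measurable value, 125000 nM, but the parent of compound 3 is not the parent of compound 4, so this is only a hint.

Compound 4 is expected to give 140000 nM, within a range of 50000 nM to 300000 nM. The expected step is an at least 1.4-fold lower number from compound 2 to compound 4 (0.15 log units; that floor lies within the scatter), a modest gain, with a real chance that this assay again reports only a limit.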

Compound 4, half-maximal inhibitory concentration: > 200000 nM
Compound 4: a limit, no number; the forecaster's own chance of this, stated with the estimate: 40%; at least 1.4-fold (0.15 log units) between middle value and limit.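

In this assay compound 4 gives only a limit, > 200000 nM, and not a number. Among the compounds shown here, compound 2 likewise gives only a limit, > 200000 nM, so no step from compound 2 to compound 4 can be read. The compounds shown leave open whether pyrrolidin-1-yl in place of ethoxy on a carbonyl carbon changes the result in this assay at all.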